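The compounds below may be only part of what the source reports. "The series", "measured", "known", "first", "only" and "open" are said of these compounds alone.

Compound 1 `S=C(Nc1ccccc1)N1N=C(c2ccccc2)CC1c1ccc2c(c1)OCCO2` gives 3180 nM in a functional assay on WM 266-4 cells (Homo sapiens) for antiproliferative activity, read by MTT assay, with a stated time of 48 h; a lower number here means a stronger inhibitor of growth, a higher number a weaker inhibitor of growth. Compound 2 `S=C(Nc1ccccc1)N1N=C(c2ccc(Cl)cc2)CC1c1ccc2c(c1)OCCO2` gives only a limit, > 200000 nM, in this assay. Compound 3 `CSc1ccc(C2=NN(C(=S)Nc3ccccc3)C(c3ccc4c(c3)OCCO4)C2)cc1` gives 197000 nM in this assay.

Compound 2 stands at the limit of > 200000 nM in this assay, at which 1 of the 3 values shown sits, and so has no number of its own. Compound 4 `S=C(Nc1ccccc1)N1N=C(c2cccc(Cl)c2)CC1c1ccc2c(c1)OCCO2` differs from compound 2 by 3-chlorophenyl in place of 4-chlorophenyl on a carbon with a double bond to nitrogen. Going by the values given here, no measured step moves a chloro between ring positions; the steps that bear on it are an at least 62-fold higher number from compound 1 to compound 2 (1.79 log units; beyond the scatter) and a 62-fold higher number from compound 1 to compound 3 (1.79 log units; beyond the scatter), both large losses on adding a group to that ring, while an at least 1.0-fold lower number from compound 2 to compound 3 (0.00 log units; that floor lies within the scatter) shows no difference within the scatter between two such groups. A chloro elsewhere on the ring is expected to cost less than in compound 2, so compound 4 is estimated at 80000 nM, between 10000 nM and 250000 nM, a step of an at least 2.5-fold lower number from compound 2 to compound 4 (0.39 log units; beyond the scatter).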

Compound 4, concentration for 50% growth inhibition: > 200000 nM
Compound 4: a limit, no number; the forecaster's own chance of this, stated with the estimate: 35%; middle value at least 2.5-fold (0.39 log units) away from the limit.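

With 3-chlorophenyl in place of 4-chlorophenyl, compound 4 also gives only a limit in this assay, so the step between it and compound 2 cannot be read, and moving the chloro does not restore growth inhibition. The chloro at this other ring position is also a large loss, an at least 62-fold higher number from compound 1 to compound 4 (1.79 log units; beyond the scatter), while an at least 1.0-fold higher number from compound 3 to compound 4 (0.00 log units; that floor lies within the scatter) shows no readable separation. Two of the compounds now sit at one limit: the limit of > 200000 nM in this assay, at which 2 of the 4 values shown sit.

Still open, from the compounds shown here alone, is whether fluoro, methoxy or an amine on this phenyl ring would stay close to compound 1 at 3180 nM.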